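Three adenosine triphosphate conjugates and an acetamide analogue

This account rests on a few compounds, and the source may have more. Where it says the series, first, only, none or still open, it means among the compounds named here.

Compound 1 `O=C(CI)NCCCC(=O)NCCCCCCNc1ncnc2c1ncn2[C@@H]1O[C@H](COP(=O)(O)OP(=O)(O)OP(=O)(O)O)[C@@H](O)[C@H]1O` gives 0% in an assay on isolated protein for inhibition of hexokinase-1 (Rattus norvegicus), with a stated time of 6 h, tested at 10 mM; a lower number here means less inhibition, a higher number more inhibition at the concentration tested (going by the name of the read-out). Compound 2 `CN(CCCCN(C)c1ncnc2c1ncn2[C@@H]1O[C@H](COP(=O)(O)OP(=O)(O)OP(=O)(O)O)[C@@H](O)[C@H]1O)C(=O)CCCCCNC(=O)CI` gives 0% in this assay, and compound 3 `O=C(CI)NCCCCCC(=O)NCCCCCCNc1ncnc2c1ncn2[C@@H]1O[C@H](COP(=O)(O)OP(=O)(O)OP(=O)(O)O)[C@@H](O)[C@H]1O` gives 0% in this assay. Compound 1 stands level with compounds 2 and 3 at the digits printed; its nearest neighbour is compound 2 and its furthest is compound 3, and neither gap exceeds the scatter. Within the data shown here, the one measured step, no change at the digits printed from compound 1 to compound 3 (within the scatter), lengthens the chain without moving the read-out.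

Compound 4 `CC(=O)NCCCCCCCCNc1ncnc2c1ncn2[C@@H]1O[C@H](COP(=O)(O)OP(=O)(O)OP(=O)(O)O)[C@@H](O)[C@H]1O` is not yet measured. It differs from compound 1 by a group of 6 heavy atoms (4 carbon, 1 nitrogen, 1 oxygen; no ring) in place of a group of 11 heavy atoms (6 carbon, 2 nitrogen, 2 oxygen, 1 iodine; no ring), on a saturated chain carbon, six bonds along the chain from a nitrogen on an aromatic ring. The step from compound 1 to compound 3 bears most directly on this change, since it also alters the same chain in the shared core, and it showed no shift. Among the measured compounds shown here, with all three measured compounds at the same level and the only available step flat, no movement beyond the scatter is expected in this assay; the expected step is no change at the digits printed from compound 1 to compound 4 (within the scatter). Compound 4 is therefore estimated at 0%, within a range of -5% to 10%.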

Compound 4, a percentage reported as inhibition, at one concentration (the size of the read-out at that concentration, not a potency): 0%
Compound 4: the middle estimate sits on the measured number at the digits printed; measured number inside the range.
By their numbers in this assay, from the lowest: compounds 1, 2, 3 and 4 (each within the scatter of the next).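

In this assay the step at this position (no change at the digits printed from compound 1 to compound 4 (within the scatter)) puts 2-acetamidoethyl, with 6 heavy atoms and no iodine, in place of a group of 11 heavy atoms that holds the iodine. Among these compounds, all the earlier compounds carried iodine, so this is the first sign that a change without it, on a saturated chain carbon, six bonds along the chain from a nitrogen on an aromatic ring, also leaves the read-out flat. Nothing measured here gives a reason for this result.

As far as these compounds go, with all four compounds level, it remains open whether any change at this position can move the read-out at all. A free amine or a carboxylic acid in place of 2-acetamidoethyl might or might not behave the same way.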